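A few compounds are considered here, and "the series" means these few. Any claim that something is new, unique, unknown or untested is made for them only; others in the source may bear on it.

In a functional assay on 786-0 cells (Homo sapiens) for cytotoxicity, read by sulforhodamine B assay, with a stated time of 48 h (on this read-out lower numbers stand for higher toxicity in this test and higher numbers for lower toxicity in this test), three compounds have been measured. Compound 2 `ClCc1cccc(Cn2cnc3c(Cl)nc(Cl)nc32)c1` gives 57500 nM. Compound 3 `ClCc1ccc(Cn2cnc3c(Cl)nc(Cl)nc32)cc1` gives 61700 nM; the two numbers lie within the usual scatter of each other, so no order between them can be read. Compound 2 and compound 3 are built from the same atoms joined differently, and the difference between the two cores is not broken down here.

Compound 1 `Nc1nc(Cl)c2ncn(Cc3ccc(CCl)cc3)c2n1` is compound 3 with one change, (amino in place of chloro on an aromatic carbon). For compound 1 this assay reports only a limit, > 100000 nM, and no number. The one limit among these values, (the limit of > 100000 nM in this assay, at which 1 of the 3 values shown sits), therefore belongs to compound 1. Measured as a step, this change gave an at least 1.6-fold higher number from compound 3 to compound 1 (0.20 log units; that floor lies within the scatter), so the real size of the step is not known and may be larger.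

Compound 4 `Nc1nc(Cl)c2ncn(Cc3cccc(CCl)c3)c2n1` is not yet measured. It stands to compound 2 as compound 1 stands to compound 3: the change is amino in place of chloro on an aromatic carbon, the same change at the same kind of place. For compound 4 a step of a 2.1-fold higher number from compound 2 to compound 4 (0.32 log units; beyond the scatter) is expected, because the same change on the other core gave an at least 1.6-fold higher number from compound 3 to compound 1 (0.20 log units; that floor lies within the scatter). Compound 4 is accordingly estimated at 120000 nM, with a likely range from 50000 nM to 300000 nM, and it may well come back as a limit rather than a number, as compound 1 did.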

Compound 4, concentration lethal to 50% of the cells: 91200 nM
Compound 4: the middle estimate sits 1.3-fold (0.12 log units) above what was measured; low and high end bracket the measured number.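

In this assay, amino in place of chloro on the aromatic carbon between two ring nitrogen atoms gave a 1.6-fold higher number from compound 2 to compound 4 (0.20 log units; within the scatter), so on this core the step cannot be told apart from the ordinary spread of repeated measurements. Set beside the earlier case, the two steps cannot be separated: the same change on two cores in this assay, an at least 1.6-fold higher number (0.20 log units; that floor lies within the scatter) from compound 3 to compound 1 and a 1.6-fold higher number (0.20 log units; within the scatter) from compound 2 to compound 4; the limit leaves it open whether they differ. The two cores therefore give no sign that the change behaves differently from one to the other, but they do not show that it carries over with the same size, or that it moves the number at all, and one of the two steps rests on a value that is only a limit: the limit of > 100000 nM in this assay, at which 1 of the 4 values shown sits.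

The compounds shown leave open what other groups would do at that same aromatic carbon, for instance a methoxy group, a methylamino group or a dimethylamino group, since only chloro and amino appear there. They also leave open how large the step to compound 1 really is, and whether the amino change would give a step beyond the scatter on any further core in this series.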